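Aryl sulfide to methoxy on a benzoylguanidine

A few compounds are considered here, and "the series" means these few. Any claim that something is new, unique, unknown or untested is made for them only; others in the source may bear on it.

Compound 1 `Cc1cc(-c2cc(Cl)cc(Cl)c2)c(S(C)(=O)=O)cc1C(=O)N=C(N)N`: 130 nM
Compound 2 `Cc1cc(Sc2ccc(Cl)cc2)c(S(C)(=O)=O)cc1C(=O)N=C(N)N`: 19 nM

For the measured compounds named here, in a functional assay for inhibition of sodium/hydrogen exchanger (Oryctolagus cuniculus) (on this read-out higher numbers stand for weaker inhibition and lower numbers for stronger inhibition), compound 2 gives the lower of the two numbers so far; the only other measured compound, compound 1, sits higher by a 6.8-fold lower number from compound 1 to compound 2 (0.84 log units; beyond the scatter), a change that came with (4-chlorophenyl)sulfanyl standing in place of 3,5-dichlorophenyl. Compound 3 `COc1cc(C)c(C(=O)N=C(N)N)cc1S(C)(=O)=O` has not yet been measured. It differs from compound 2 in one place: methoxy in place of (4-chlorophenyl)sulfanyl on an aromatic carbon. Going by the values given here, the one measured step bears on this only loosely, since it swapped one aromatic substituent for another at the same position and still moved the number by a modest amount; here the ring leaves entirely and a far smaller group enters. A weaker result is therefore expected for compound 3, by about a 26-fold higher number from compound 2 to compound 3 (1.42 log units; beyond the scatter). Compound 3 is estimated at 500 nM in this assay, with a range from 100 nM to 3000 nM.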

Compound 3, half-maximal inhibitory concentration: 16 nM
The estimate for compound 3 lay 31-fold (1.49 log units) above the measured number; the measured number lies below the stated range.
By their numbers in this assay, from the lowest: compounds 3 and 2 (each within the scatter of the next); then compound 1.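

In this assay, methoxy in place of (4-chlorophenyl)sulfanyl gives a 1.2-fold lower number from compound 2 to compound 3 (0.07 log units; within the scatter) and so no readable change, which shows that the aromatic ring of the sulfide is not needed at this position, ortho to the methylsulfonyl group, for a number this low. Methoxy in place of 3,5-dichlorophenyl gives an 8.1-fold lower number from compound 1 to compound 3 (0.91 log units; beyond the scatter) and this step lies beyond the scatter, so a group with no ring at all can give a clearly lower number than the directly attached dichlorophenyl ring. Nothing available here explains either step.

As far as these compounds go, whether an amine, a hydroxyl group or a longer chain such as ethoxy at this position would keep the number this low remains open. Also open, from the compounds shown here alone, is whether methoxy would hold up if the methyl group or the methylsulfonyl group on the shared core were changed.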